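From 4-chlorophenyl to 3-chlorophenyl on a sulfonyl chain carbon

This account rests on a few compounds, and the source may have more. Where it says the series, first, only, none or still open, it means among the compounds named here.

compound 1 `O=C(OCCCc1cccnc1)C1CCCCN1C(=O)COc1ccc(Cl)cc1` gives 50900 nM
compound 2 `O=C(OCCCc1cccnc1)[C@@H]1CCCCN1S(=O)(=O)Cc1ccc(Cl)cc1` gives 33600 nM

In a toxicity assay (J774.1 cells) for cytotoxicity, with Mus musculus as the target, read by resazurin assay, with a stated time of 24 h (on this read-out higher numbers stand for weaker inhibition and lower numbers for stronger inhibition), compound 2 stands at 33600 nM, within the scatter of compound 1, so the two numbers do not separate. Compound 3 `O=C(OCCCc1cccnc1)[C@@H]1CCCCN1S(=O)(=O)Cc1cccc(Cl)c1` differs from compound 2 on a saturated chain carbon bound to a sulfonyl sulfur: 3-chlorophenyl in place of 4-chlorophenyl on a saturated chain carbon bound to a sulfonyl sulfur. Within the data shown here, no measured pair shows this change, so no step beyond the scatter is expected in this assay. The expected step, a 1.0-fold higher number from compound 2 to compound 3 (0.02 log units; within the scatter), is estimated to stay within the scatter. For compound 3 the estimated value is 35000 nM, with an expected range from 17000 nM to 70000 nM.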

Compound 3, half-maximal inhibitory concentration: 43300 nM
The estimate for compound 3 lay 1.2-fold (0.09 log units) below the measured number, and the stated range covers the measured number.
By their numbers in this assay, from the lowest: compounds 2, 3 and 1 (each within the scatter of the next).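

Among these compounds, replacing 4-chlorophenyl with 3-chlorophenyl on a saturated chain carbon bound to a sulfonyl sulfur gives a 1.3-fold higher number from compound 2 to compound 3 (0.11 log units; within the scatter) in this assay and provides the first reading at this position. Within the scatter, this change does not separate the two compounds, so the chlorine's placement on this phenyl ring has no resolved effect on this read-out. Nothing measured here offers an explanation for this result.

Going by these compounds, whether an amine in place of the chlorine, or a longer chain in place of the saturated chain carbon, would give a step beyond the scatter remains open.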